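Carbamoyl in place of tetrazole on compound 3

A few compounds are considered here, and "the series" means these few. Any claim that something is new, unique, unknown or untested is made for them only; others in the source may bear on it.

Measured so far:
compound 1 `N#Cc1cccc(-c2cnc(C(=O)CCc3ccc(-c4ccccc4)cc3)o2)n1` — 2.9 nM
compound 2 `CN(C)C(=O)c1cnc(C(=O)CCc2ccc(-c3ccccc3)cc2)o1` — 3 nM
compound 3 `O=C(CCc1ccc(-c2ccccc2)cc1)c1ncc(-c2cccc(-c3nnn[nH]3)n2)o1` — 25 nM

In an assay for inhibition of Fatty-acid amide hydrolase 1 (Rattus norvegicus) (a lower number here means a stronger inhibitor, a higher number a weaker inhibitor), compound 3 stands at the highest number of the three, beyond the scatter from both compound 1 and compound 2, which sit within the scatter of each other. The next compound, compound 4 `NC(=O)c1cccc(-c2cnc(C(=O)CCc3ccc(-c4ccccc4)cc3)o2)n1`, differs from compound 3 in one place: carbamoyl in place of 1H-tetrazol-5-yl on an aromatic carbon. The measured step that bears on this change is an 8.6-fold higher number from compound 1 to compound 3 (0.94 log units; beyond the scatter), which shows that the tetrazole at this position costs potency relative to the nitrile. Among the compounds with values here, the step of a 1.0-fold higher number from compound 1 to compound 2 (0.01 log units; within the scatter) concerns a dimethylcarbamoyl at a different place on the core and says only that a carboxamide group is tolerated somewhere. Within the data shown here, no compound carries a carbamoyl at the position now changed, so the size of the step for compound 4 rests on the one relevant comparison. Moving from the tetrazole back toward a smaller group is expected to recover part of the loss seen in compound 3, without full confidence of reaching compound 1. Compound 4 is therefore estimated at 6 nM, with a range of 2 nM to 20 nM. The expected step is a 4.2-fold lower number from compound 3 to compound 4 (0.62 log units; beyond the scatter), a lower number, likely beyond the scatter.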

Compound 4, inhibition constant: 1.2 nM
Compound 4: the middle estimate sits 5.0-fold (0.70 log units) above what was measured, and the stated range ends above it.
By their numbers in this assay, from the lowest: compound 4; then compounds 1 and 2 (each within the scatter of the next); then compound 3.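

In this assay, carbamoyl in place of 1H-tetrazol-5-yl gives a 21-fold lower number from compound 3 to compound 4 (1.32 log units; beyond the scatter), so the high number of compound 3 does not extend to every group at this place on the six-membered aromatic ring. The carbamoyl does more than recover the ground lost to the tetrazole: carbamoyl in place of cyano gives a 2.4-fold lower number from compound 1 to compound 4 (0.38 log units; beyond the scatter), which shows that the nitrile of compound 1 was not the best group tested here and that this position still separates groups at low nanomolar numbers. The step of a 2.5-fold lower number from compound 2 to compound 4 (0.40 log units; beyond the scatter) also puts compound 4 beyond the scatter of the dimethylcarbamoyl compound, making compound 4 the most potent of the four, with steps to all three others printed as beyond the scatter.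

No measurement on hand explains this order of carbamoyl, nitrile and tetrazole. Open, as far as these compounds go, is whether a carboxylic acid, a methylcarbamoyl or a dimethylcarbamoyl at this same place would stay with compound 4 or move toward compound 3, which would show how much of the gain depends on the amide hydrogens.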